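The compounds below may be only part of what the source reports. "The series", "measured", "known", "first", "only" and "open" are said of these compounds alone.

Measured compounds:
compound 1, `CN(CCCCN(C)C(=O)CCCNc1ncnc2c1ncn2[C@@H]1O[C@H](COP(=O)(O)OP(=O)(O)OP(=O)(O)O)[C@@H](O)[C@H]1O)C(=O)CCCNC(=O)CI`, giving 0%
compound 2, `O=C(CI)NCCCCNc1ncnc2c1ncn2[C@@H]1O[C@H](COP(=O)(O)OP(=O)(O)OP(=O)(O)O)[C@@H](O)[C@H]1O`, giving 0%

In an assay on isolated protein for inhibition of hexokinase-1 (Rattus norvegicus), with a stated time of 6 h, tested at 10 mM (a lower number here means less inhibition, a higher number more inhibition at the concentration tested (going by the name of the read-out)), compound 1 gives 0%. In this assay compound 2 gives 0%. Compound 2 stands level with compound 1 at the digits shown; the two values lie within the scatter, so no order between them can be read, and neither compound shows measurable inhibition at the concentration tested. Among the measured compounds shown here, no step between measured compounds that differ in one place is available, so the effect of a single structural change on the read-out is unknown.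

Compound 3, `O=C(CI)NCCC(=O)NCCCCCCNc1ncnc2c1ncn2[C@@H]1O[C@H](COP(=O)(O)OP(=O)(O)OP(=O)(O)O)[C@@H](O)[C@H]1O`, is not yet measured. It differs from compound 2 in one place: a group of 12 heavy atoms (7 carbon, 2 nitrogen, 2 oxygen, 1 iodine; no ring) in place of a group of 5 heavy atoms (2 carbon, 1 nitrogen, 1 oxygen, 1 iodine; no ring), on a saturated chain carbon, four bonds along the chain from a nitrogen on an aromatic ring. Both measured compounds sit at zero, and a larger group entering at the same place gives no ground for a change. The step of a number 2 percentage points higher from compound 2 to compound 3 (within the scatter) is expected to stay within the scatter. Compound 3 is estimated at 2%, in the range 0% to 15%.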

Compound 3, a percentage reported as inhibition, at one concentration (the size of the read-out at that concentration, not a potency): 0%
Estimate against measurement, compound 3: 2 percentage points above, and the stated range covers the measured number.
By their numbers in this assay, from the lowest: compounds 1, 2 and 3 (each within the scatter of the next).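

In this assay, the series now has its first step in one place: the group of 12 heavy atoms in place of ((iodomethyl)carbonyl)amino, on a saturated chain carbon, four bonds along the chain from a nitrogen on an aromatic ring, reads no change at the digits printed from compound 2 to compound 3 (within the scatter). At this place, then, the larger group, with its second hydrogen-bond donor and acceptor, does not lift the read-out from the level of the smaller one, although a step that starts and ends at zero cannot separate the two groups any further. No measurement bearing on this result is at hand.

As far as these compounds go, whether an amine, a carboxylic acid or a longer chain at this place would give any inhibition stays open. Also open, from the compounds shown here alone, is how much of this position can be changed once a compound with a read-out above zero is available as a reference.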